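The source may report more compounds than this note shows. Statements on the series, on what has been measured and on what is new or still open speak of the compounds shown alone.

In an ADME assay on microsomes from liver (Homo sapiens) for metabolic stability, read by LC-MS, using NADPH, with a stated time of 30 min, tested at 1 uM (a lower number here means slower removal, a higher number faster removal of the compound), two compounds have values so far:

compound 1 `Cc1cc2c(cn1)Oc1ccc(NC(=O)c3ccc(Cl)cn3)cc1[C@@]21COC(N)=N1` gives 16 mL.min-1.g-1 in this assay
compound 2 `NC1=N[C@@]2(CO1)c1cc(-c3cncc(C#CC4CC4)c3)ccc1Oc1cnc(C3=CCOCC3)cc12` gives 80 mL.min-1.g-1 in this assay

Compound 2 has the higher of the two numbers, and its gap to compound 1 lies beyond the usual scatter. The two compounds differ in more than one place, so that gap isolates no single change.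

Compound 3 `NC1=N[C@@]2(CO1)c1cc(-c3cncc(C#CCO)c3)ccc1Oc1cnc(C3=CCOCC3)cc12` has hydroxymethyl in place of cyclopropyl on a triple-bonded carbon and is otherwise identical to compound 2. Going by the values given here, no measured pair differing in one place offers a precedent, so the expectation rests on this structural change alone. A moderate move towards slower removal is expected, perhaps only just beyond the scatter. The estimate is a 2.3-fold lower number from compound 2 to compound 3 (0.36 log units; beyond the scatter) in this assay as the expected step. Compound 3 is expected at 35 mL.min-1.g-1 with an estimated range of 15 mL.min-1.g-1 to 70 mL.min-1.g-1 for its measurement.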

Compound 3, intrinsic clearance in microsomes: 84 mL.min-1.g-1
For compound 3 the middle estimate is 2.4-fold (0.38 log units) below the measured one; the measured number lies above the stated range.
By their numbers in this assay, from the lowest: compound 1; then compounds 2 and 3 (each within the scatter of the next).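

In this assay, going by these compounds alone, the one-place exchange at the triple-bonded carbon gives a 1.1-fold higher number from compound 2 to compound 3 (0.02 log units; within the scatter), the first step in this set that isolates a single change. At this position, hydroxymethyl in place of cyclopropyl takes out the three-membered ring and brings in a hydrogen-bond donor and acceptor, yet the two compounds cannot be told apart in this read-out. No available evidence explains this result.

On these data alone, whether an amine, a carboxylic acid or a longer chain at the same carbon would also stay within the scatter of compound 2 remains open. The compounds shown also do not tell which of the several differences between compound 1 and compound 2 accounts for the gap between their values.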